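Chain-extended amines

The source may hold more compounds than are shown below. What is called first, only, known or untested is meant among the compounds shown, and "the series" means these compounds.

Compound 3 `COc1cc(/C=C/C(=O)Nc2ccccc2)ccc1OCCCCCCN1CCCCC1` is the reference here. In a physicochemical assay for lipophilicity, using the shake flask method, measured as octanol-water partition, at pH 7.4 (a higher number here means a more lipophilic compound, a lower number a more polar compound), compound 3 gives 1.77; compound 2 `COc1cc(/C=C/C(=O)Nc2ccccc2)ccc1OCCCN1CCCC1` gives 1.57 and compound 1 `COc1cc(/C=C/C(=O)Nc2ccccc2)ccc1OCCCN(C)C` gives 1.55, so the three numbers sit within the scatter of one another. Compound 4 `COc1cc(/C=C/C(=O)Nc2ccccc2)ccc1OCCCCCCCCCCN1CCCC1` differs from compound 3 by 4-(pyrrolidin-1-yl)butyl in place of piperidin-1-yl on a saturated chain carbon, six bonds along the chain from an oxygen on an aromatic ring. The measured steps that bear on this are a number 0.02 log units higher from compound 1 to compound 2 (within the scatter), a number 0.22 log units higher from compound 1 to compound 3 (within the scatter) and a number 0.20 log units higher from compound 2 to compound 3 (within the scatter); exchanging one small amine for another moved nothing, and lengthening the chain by the 3-(piperidin-1-yl)propyl group gave only a small rise. The further lengthening in compound 4 is therefore expected to raise this assay slightly, about a number 0.23 log units higher from compound 3 to compound 4 (within the scatter), a step near the edge of the scatter. Compound 4 is estimated at 2, between 1.6 and 2.5.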

Compound 4, partition coefficient: 1.86
Compound 4: the middle estimate sits 0.14 log units above what was measured; low and high end bracket the measured number.
By their numbers in this assay, from the lowest: compounds 1, 2, 3 and 4 (each within the scatter of the next, the first and the last beyond it).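

In this assay, 4-(pyrrolidin-1-yl)butyl in place of piperidin-1-yl at this position gives a number 0.09 log units higher from compound 3 to compound 4 (within the scatter), so even this long extension stays within the scatter of compound 3. Only across the whole series do the printed values separate: compound 1 gives 1.55 and compound 4 gives 1.86, a gap beyond the scatter. No measurement available here accounts for the step.

The step alters ring and chain together, and their shares cannot be separated. From the compounds shown here alone, a morpholine at the chain end, or a still longer chain, remains open.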